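Branching the Ester Chain: From Butyl to Tert-Butyl

A few compounds are considered here, and "the series" means these few. Any claim that something is new, unique, unknown or untested is made for them only; others in the source may bear on it.

For the measured compounds named here, compound 3 `CCCCOC(=O)/C=C/c1ccc2c(c1)C(=O)C(=O)N2Cc1ccc(OC)cc1` gives 220 nM in a functional assay on Jurkat cells (Homo sapiens) for antiproliferative activity, read by MTT assay, with a stated time of 48 h (on this read-out lower numbers stand for stronger inhibition and higher numbers for weaker inhibition), the highest of the three numbers measured so far. Compound 1 `COC(=O)/C=C/c1ccc2c(c1)C(=O)C(=O)N2Cc1ccc(OC)cc1` gives 30 nM and compound 2 `CCOC(=O)/C=C/c1ccc2c(c1)C(=O)C(=O)N2Cc1ccc(OC)cc1` gives 30 nM in this assay. The change from a methyl to an ethyl ester gave no change at the digits printed from compound 1 to compound 2 (within the scatter), whereas growing the chain further gave a 7.3-fold higher number from compound 1 to compound 3 (0.87 log units; beyond the scatter) and a 7.3-fold higher number from compound 2 to compound 3 (0.87 log units; beyond the scatter). Compound 4 `COc1ccc(CN2C(=O)C(=O)c3cc(/C=C/C(=O)OC(C)(C)C)ccc32)cc1` differs from compound 3 by tert-butyl in place of butyl on an oxygen next to a carbonyl group. The two have the same atoms joined differently; the measured steps concern chain length and leave branching untested. The expected change in this assay is a 1.2-fold lower number from compound 3 to compound 4 (0.09 log units; within the scatter), a modest move and possibly none beyond the scatter. Compound 4 is estimated at 180 nM, with a range from 60 nM to 600 nM.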

Compound 4, half-maximal inhibitory concentration: 310 nM
Compound 4: the middle estimate sits 1.7-fold (0.24 log units) below what was measured; measured number inside the range.
By their numbers in this assay, from the lowest: compounds 1 and 2 (each within the scatter of the next); then compounds 3 and 4 (each within the scatter of the next).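

Rearranging the butyl chain into tert-butyl on this ester oxygen has little effect in this assay (a 1.4-fold higher number from compound 3 to compound 4 (0.15 log units; within the scatter)), so branching at this position makes no difference beyond the scatter. The size of the group still matters: tert-butyl in place of ethyl gives (a 10-fold higher number from compound 2 to compound 4 (1.01 log units; beyond the scatter)), and tert-butyl in place of methyl gives (a 10-fold higher number from compound 1 to compound 4 (1.01 log units; beyond the scatter)). Nothing available here explains these numbers. Still open, from the compounds shown here alone, is whether a smaller branched group such as isopropyl, or a carboxylic acid in place of the ester, would stay near compound 1 and compound 2.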